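The source may hold more compounds than are shown below. What is called first, only, known or untested is meant among the compounds shown, and "the series" means these compounds.

Of the compounds shown here, three have so far been measured in an assay on isolated protein (Bos taurus) with 5-hydroxytryptamine receptor 1D (Homo sapiens) as the target; on this read-out lower numbers stand for stronger inhibition and higher numbers for weaker inhibition. Compound 1 `c1ccc2c(c1)CCC(CNCCCCCNC1=NCCCN1)O2` gives 10 nM, compound 2 `COc1cccc2c1OC(CNCCCNC1=NCCCN1)CC2` gives 0.794 nM, and compound 3 `c1cnc(NCCCNCC2CCc3ccccc3O2)nc1` gives 1.59 nM. Compound 3 therefore holds the second highest number of the three: its gap to compound 2 lies within the usual scatter, while its gap to compound 1 lies beyond it. Compound 4 `c1ccc2c(c1)CCC(CNCCCNc1cnccn1)O2` has not yet been measured. It differs from compound 3 in one place: pyrazin-2-yl in place of pyrimidin-2-yl on an amine nitrogen. Within the data shown here, no measured pair shows this swap, so nothing in the data fixes its size; a small step is expected, leaning toward a somewhat higher number in this assay. The expected step is a 1.9-fold higher number from compound 3 to compound 4 (0.28 log units; within the scatter). Compound 4 is estimated at 3 nM, with a range from 0.8 nM to 12 nM.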

Compound 4, half-maximal inhibitory concentration: 10 nM
Compound 4: middle estimate off by 3.3-fold (0.52 log units), on the low side, within the range that was stated.
By their numbers in this assay, from the lowest: compounds 2 and 3 (each within the scatter of the next); then compounds 1 and 4 (each within the scatter of the next).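

The two groups hold the same atoms, joined differently, and the same counts of donors and acceptors, yet pyrazin-2-yl in place of pyrimidin-2-yl on this amine nitrogen gives a 6.3-fold higher number from compound 3 to compound 4 (0.80 log units; beyond the scatter) in this assay. Among these compounds, the earlier compounds offered no single change at this place, so this is the first sign that the arrangement of atoms in this ring affects the number. Nothing available explains the gap. Still open, as far as these compounds go, is how a pyridin-2-yl or phenyl group would read on this nitrogen, and whether the same swap gives a similar step with a longer chain.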